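Carrying an Ethoxy Step From One Core to Another

The source may report more compounds than this note shows. Statements on the series, on what has been measured and on what is new or still open speak of the compounds shown alone.

Compound 1 `COc1ccc(S(=O)(=O)Nc2cccc3[nH]nc(Cl)c23)cc1` and compound 2 `CCOc1ccc(NS(=O)(=O)c2ccc(OC)cc2)c2c(Cl)n[nH]c12` share one core, while compound 3 `C=CCn1cc2ccc(NS(=O)(=O)c3ccc(C)cc3)cc2n1` and compound 4 `C=CCn1cc2ccc(NS(=O)(=O)c3ccc(C)cc3)c(OCC)c2n1` share another. How the two cores differ is not broken down here. In a functional assay on A2780 cells (Homo sapiens) for cytotoxicity, read by MTT assay, with a stated time of 72 h (a lower number here means a stronger inhibitor, a higher number a weaker inhibitor), compound 1 gives 860 nM, and compound 2 gives 1230 nM. The change between them is ethoxy in place of hydrogen on an aromatic carbon, and it produced a 1.4-fold higher number from compound 1 to compound 2 (0.16 log units; within the scatter). In this assay compound 3 gives 4890 nM, a higher number than both compound 1 and compound 2, beyond the scatter in each case. Compound 4 carries the same kind of change as compound 2, namely (ethoxy in place of hydrogen on an aromatic carbon), but the place is not the same: in compound 2 the new group sits para to a large group, whereas in compound 4 it sits ortho to a large group. Among the measured compounds shown here, with only one measured example, and that on a different core, the expectation rests on the earlier step alone. For compound 4 the expected step is a 1.2-fold higher number from compound 3 to compound 4 (0.09 log units; within the scatter), comparable to a 1.4-fold higher number from compound 1 to compound 2 (0.16 log units; within the scatter). Compound 4 is therefore estimated at 6000 nM, within a range of 2500 nM to 14000 nM.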

Compound 4, half-maximal inhibitory concentration: > 100000 nM
Compound 4 gave a limit, no number; the forecaster's own chance of this, stated with the estimate: 10%; at least 16-fold (1.22 log units) between middle value and limit.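

In this assay, ethoxy in place of hydrogen gave an at least 20-fold higher number from compound 3 to compound 4 (1.31 log units; beyond the scatter), so on the core of compound 3 the same change had a far larger effect than on the core of compound 1: the same change on two cores in this assay, a 1.4-fold higher number (0.16 log units; within the scatter) from compound 1 to compound 2 and an at least 20-fold higher number (1.31 log units; beyond the scatter) from compound 3 to compound 4, at least 14-fold (1.15 log units) apart, beyond the scatter of two such steps

Compound 4 gave > 100000 nM, which is a limit of the assay and not a number, so the full size of this step stays unknown: the limit of > 100000 nM in this assay, at which 1 of the 4 values shown sits.

The result shows that a step measured on one core cannot safely be carried to another in this series, but it does not show that the core alone is responsible, since the ethoxy in compound 4 sits ortho to a large group and its place in compound 2 is not the same.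

The compounds shown leave open what ethoxy would do in one and the same place on both cores. They also leave open whether a hydroxyl group, an amine or a longer chain in the place of that ethoxy on the core of compound 3 would give a measurable number in this assay.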